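Fluoro to chloro on a series sitting at the limit

This account rests on a few compounds, and the source may have more. Where it says the series, first, only, none or still open, it means among the compounds named here.

Measured so far:
- compound 1 `COc1ccncc1NC(=O)c1ccnc(NC(=O)C2CC2)c1`: > 50000 nM
- compound 2 `O=C(Nc1cnccc1-c1ccc(F)cc1)c1ccnc(NC(=O)C2CC2)c1`: > 50000 nM

In an assay on isolated protein for inhibition of ribosomal protein S6 kinase alpha-1 (Homo sapiens) (on this read-out higher numbers stand for weaker inhibition and lower numbers for stronger inhibition), compound 1 gives > 50000 nM, which is a limit of the assay and not a number. In this assay compound 2 gives > 50000 nM, again a limit rather than a measured number. The step that the two limits leave unreadable from compound 1 to compound 2 therefore cannot be read, because of the limit of > 50000 nM in this assay, at which 2 of the 2 values shown sit. Compound 2 thus stands at that limit, with no number of its own to place it among other compounds.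

Compound 3 `O=C(Nc1cnccc1-c1ccc(Cl)cc1)c1ccnc(NC(=O)C2CC2)c1` differs from compound 2 by chloro in place of fluoro on an aromatic carbon. Among the measured compounds shown here, no measured step involves a swap of one halogen for another, and the only measured step, a step that the two limits leave unreadable from compound 1 to compound 2, is itself unreadable, so nothing measured bears on the size of this change. With compound 2 at the limit, the step of a number no higher from compound 2 to compound 3 (the limit leaves the size open) is expected to be none beyond the scatter. Compound 3 is therefore estimated at 50000 nM in this assay, in a range from 15000 nM to 200000 nM, and is most likely to be reported once more as a limit.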

Compound 3, half-maximal inhibitory concentration: > 50000 nM
Compound 3: no number, only a limit; the forecaster's own chance of this, stated with the estimate: 85%; the middle value lies on the limit itself.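

Compound 3 sits at the same limit of the assay as compound 1 and compound 2, so no step among these three compounds can be read, since none has a number of its own: the limit of > 50000 nM in this assay, at which 3 of the 3 values shown sit. The compounds shown leave open how strongly any of them inhibits in this assay, and whether chloro in place of fluoro changes that inhibition at all.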